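Aryl swaps on the spiro core: toward compound 4

The compounds below may be only part of what the source reports. "The series", "measured", "known", "first", "only" and "open" are said of these compounds alone.

In a functional assay on MV4-11 cells (Homo sapiens) for inhibition, read by resazurin assay, with a stated time of 72 h (on this read-out higher numbers stand for weaker inhibition of growth and lower numbers for stronger inhibition of growth), compound 1 , `O=C1NCCC12CCN(c1c(Cl)cncc1-c1ccco1)CC2`, gives 940 nM, the highest of the three numbers recorded so far. Compound 2 , `O=C1NCCC12CCN(c1c(Cl)cncc1-c1ccsc1)CC2`, gives 190 nM, and compound 3 , `Cc1csc(-c2cncc(Cl)c2N2CCC3(CCNC3=O)CC2)c1`, gives 650 nM in this assay. The step of a 4.9-fold lower number from compound 1 to compound 2 (0.69 log units; beyond the scatter) was a clear gain, whereas the step of a 1.4-fold lower number from compound 1 to compound 3 (0.16 log units; within the scatter) stayed within the scatter; between the two thiophene variants the step of a 3.4-fold higher number from compound 2 to compound 3 (0.53 log units; beyond the scatter) ran the other way.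

Compound 4 , `O=C1NCCC12CCN(c1c(Cl)cncc1-c1ccc(Cl)s1)CC2`, differs from compound 1 in one place: 5-chlorothiophen-2-yl in place of furan-2-yl on an aromatic carbon. Among the compounds with values here, two measured steps bear on it. Compound 3 shows that a thiophen-2-yl carrying a small substituent changes little against compound 1, as seen in a 1.4-fold lower number from compound 1 to compound 3 (0.16 log units; within the scatter). Compound 2 shows that a thiophene in place of the furan can lower the number, as seen in a 4.9-fold lower number from compound 1 to compound 2 (0.69 log units; beyond the scatter). Within the data shown here, the entering group is a thiophen-2-yl, as in compound 3, so the nearer precedent is the small step; a chloro substituent on the thiophene has no precedent in this set. A modest lowering, or none beyond the scatter, is therefore the expectation, with the range kept wide.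

For compound 4 the expected value in this assay is 450 nM, within 150 nM to 1300 nM. The expected step is a 2.1-fold lower number from compound 1 to compound 4 (0.32 log units; beyond the scatter).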

Compound 4, concentration for 50% growth inhibition: 560 nM
The estimate for compound 4 lay 1.2-fold (0.09 log units) below the measured number, and the stated range covers the measured number.
By their numbers in this assay, from the lowest: compound 2; then compounds 4, 3 and 1 (each within the scatter of the next).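

Swapping the furan-2-yl for 5-chlorothiophen-2-yl at this position gives a 1.7-fold lower number from compound 1 to compound 4 (0.22 log units; within the scatter), and swapping the 4-methylthiophen-2-yl for the same group gives a 1.2-fold lower number from compound 3 to compound 4 (0.06 log units; within the scatter), so neither a chloro nor a methyl substituent on a thiophen-2-yl separates from the furan-2-yl here. The thiophen-3-yl group of compound 2 still stands apart, with a 2.9-fold higher number from compound 2 to compound 4 (0.47 log units; beyond the scatter), which adds a third group to the two already separated from it, though compounds 1, 3 and 4 themselves remain unresolved from one another. No measurement on hand accounts for this gap.

Among the compounds shown, every thiophen-2-yl carries a substituent and the only thiophen-3-yl carries none, so the attachment point and the substituent cannot be told apart as the source of the gap; an unsubstituted thiophen-2-yl would bear directly on this. From the compounds shown here alone, whether a 5-chlorothiophen-3-yl, or a thiophen-3-yl carrying an amine or a carboxylic acid, keeps the number of compound 2 also stays open.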